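The source may report more compounds than this note shows. Statements on the series, on what has been measured and on what is new or still open speak of the compounds shown alone.

Compound 1 `CCCCCCCC/C=C\CCCCCCCC(=O)OC[C@@H](C)OP(=O)(O)OC[C@H](N)C(=O)O` is examined in an assay on HEK293 cells for agonist activity at probable G-protein coupled receptor 34 (Mus musculus), with a stated time of 1 h (a higher number here means a larger maximal response, a lower number a smaller maximal response), where compound 1 reaches 12.8%. Its only comparator, compound 2 `CCCCCCCC/C=C\CCCCCCCC(=O)OC[C@H](C)OP(=O)(O)OC[C@H](N)C(=O)O`, gives 11.2% in this assay, and the change a number 1.6 percentage points lower from compound 1 to compound 2 (within the scatter) rests on a stereochemical point alone (the fact that one of compounds 1 and 2 is drawn with a defined configuration and the other without, at the place where they differ). Compound 3 `CCCCCCCC/C=C\CCCCCCCC(=O)OC[C@@H](COC)OP(=O)(O)OC[C@H](N)C(=O)O` differs from compound 1 by methoxy in place of hydrogen on a saturated chain carbon, two bonds along the chain from an oxygen on an unsaturated carbon. Going by the values given here, no measured step bears on a change of this kind, so the direction of its effect in this assay cannot be read from the two numbers in hand. Compound 3 is therefore expected to stay near compound 1, at an estimated 12% (range 4% to 25%), a step of a number 0.8 percentage points lower from compound 1 to compound 3 (within the scatter) expected to be within the scatter.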

Compound 3, largest response reached (Emax), in percent of the reference or control that the assay uses: 12.9%
Estimate against measurement, compound 3: 0.9 percentage points below; measured number inside the range.
By their numbers in this assay, from the lowest: compounds 2, 1 and 3 (each within the scatter of the next).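

Moving from methyl to methoxymethyl at this saturated chain carbon, two bonds along the chain from an oxygen on an unsaturated carbon, gives a number 0.1 percentage points higher from compound 1 to compound 3 (within the scatter) in this assay. The position therefore carries a methoxy group with a maximal response that cannot be told apart from that of compound 1, something the stereochemical pair of compound 1 and compound 2 could not show. Nothing available gives a reason for this step. On these data alone, whether an amine, a carboxylic acid or a longer chain at this carbon would shift the response remains open.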